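A few compounds are considered here, and "the series" means these few. Any claim that something is new, unique, unknown or untested is made for them only; others in the source may bear on it.

Measured compounds in a functional assay on NCI-H322M cells (Homo sapiens) for antiproliferative activity, with a stated time of 48 h; a higher number here means a weaker inhibitor of growth, a lower number a stronger inhibitor of growth:
compound 1 `Cc1cc(O)c(C2=NN(c3ccc(S(N)(=O)=O)cc3)C(c3ccccc3O)C2)cc1Cl`, 2500 nM
compound 2 `Cc1cc(O)c(C2=NN(c3ccc(S(N)(=O)=O)cc3)C(c3ccccc3Cl)C2)cc1Cl`, 2190 nM
compound 3 `COc1ccc(C2CC(c3cc(Cl)c(C)cc3O)=NN2c2ccc(S(N)(=O)=O)cc2)cc1OC`, 4450 nM

Compound 1 holds the second highest of the three numbers in this assay; its nearest neighbour is compound 2, with a 1.1-fold lower number from compound 1 to compound 2 (0.06 log units; within the scatter), and its furthest is compound 3, with a 1.8-fold higher number from compound 1 to compound 3 (0.25 log units; within the scatter). The remaining measured step is a 2.0-fold higher number from compound 2 to compound 3 (0.31 log units; beyond the scatter).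

Compound 4 `COc1ccc(C2CC(c3cc(Cl)c(C)cc3O)=NN2c2ccc(S(N)(=O)=O)cc2)c(OC)c1OC` has not yet been measured in this assay. It differs from compound 1 in one place: 2,3,4-trimethoxyphenyl in place of 2-hydroxyphenyl on a saturated ring carbon. The two steps that bear on this change are those that replace the group on the same saturated ring carbon with 3,4-dimethoxyphenyl, namely a 1.8-fold higher number from compound 1 to compound 3 (0.25 log units; within the scatter) and a 2.0-fold higher number from compound 2 to compound 3 (0.31 log units; beyond the scatter); both point to a somewhat higher number, the first within the scatter, the second just beyond it. The entering 2,3,4-trimethoxyphenyl group is close to the 3,4-dimethoxyphenyl of compound 3, so a step of about the same size and direction is expected.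

Compound 4 is therefore estimated at 4500 nM in this assay, with a plausible range of 2200 nM to 9000 nM. The expected step is a 1.8-fold higher number from compound 1 to compound 4 (0.26 log units; within the scatter), resting on compound 3 and its step of a 1.8-fold higher number from compound 1 to compound 3 (0.25 log units; within the scatter).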

Compound 4, concentration for 50% growth inhibition: 2860 nM
Beside the measured number, compound 4's estimate is 1.6-fold (0.20 log units) above it, within the range that was stated.
By their numbers in this assay, from the lowest: compounds 2, 1, 4 and 3 (each within the scatter of the next, the first and the last beyond it).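

In this assay, among these compounds, the saturated ring carbon next to the ring nitrogen accepts 2,3,4-trimethoxyphenyl in place of 2-hydroxyphenyl with no step beyond the scatter (a 1.1-fold higher number from compound 1 to compound 4 (0.06 log units; within the scatter)), and the same holds for its replacement of 2-chlorophenyl (a 1.3-fold higher number from compound 2 to compound 4 (0.12 log units; within the scatter)), so neither the hydroxy nor the chloro of the earlier compounds is needed at this position to stay within the scatter of those compounds. Methoxy in place of hydrogen on the aromatic ring of compound 3 also stays within the scatter (a 1.6-fold lower number from compound 3 to compound 4 (0.19 log units; within the scatter)), and since compound 4 also carries methoxy groups at this position, the modest gap seen earlier (a 2.0-fold higher number from compound 2 to compound 3 (0.31 log units; beyond the scatter)) does not extend to every methoxy-bearing phenyl group here. No measurement of any other kind is available to account for these steps.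

As far as these compounds go, all groups at this carbon so far are substituted phenyl rings, so it remains open whether the same picture holds for a phenyl ring carrying an amine or a carboxylic acid, or for a short alkyl chain in place of the ring. The 4-sulfamoylphenyl and 5-chloro-2-hydroxy-4-methylphenyl groups are common to all four compounds, so what each contributes cannot be read from this set.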